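Chloro to amino on the fused ring: next step

The source may report more compounds than this note shows. Statements on the series, on what has been measured and on what is new or still open speak of the compounds shown alone.

In a functional assay on CCRF-CEM cells (Homo sapiens) for antiproliferative activity, read by sulforhodamine B assay, with a stated time of 48 h (on this read-out lower numbers stand for stronger inhibition of growth and higher numbers for weaker inhibition of growth), compound 1 `Nc1nn(C(=O)Nc2ccc(Cc3ccccc3)cc2)c2ccccc12` gives "not determined" (no result reported), so no result stands for it. Among the compounds with values here, compound 2 `Nc1nn(C(=O)Nc2ccc(Cc3ccccc3)cc2)c2ccc(Cl)cc12` is the only compound with a number in this assay, giving 34400 nM; nothing else can be set beside it. Compound 3 `Nc1ccc2c(c1)c(N)nn2C(=O)Nc1ccc(Cc2ccccc2)cc1` differs from compound 2 by amino in place of chloro on an aromatic carbon. Within the data shown here, no comparable step has been measured, so the direction is open; the expected step from compound 2 to compound 3 is a 1.2-fold higher number from compound 2 to compound 3 (0.07 log units; within the scatter), a change not clearly beyond the scatter. Compound 3 is estimated at 40000 nM in this assay, with a range from 15000 nM to 110000 nM.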

Compound 3, concentration for total growth inhibition: 18800 nM
The estimate for compound 3 lay 2.1-fold (0.33 log units) above the measured number; the measured number falls inside the stated range.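

In this assay, within the data shown here, amino in place of chloro on an aromatic carbon gives a 1.8-fold lower number from compound 2 to compound 3 (0.26 log units; within the scatter), the first step that can be read at this position of the series. The position therefore accepts either chloro or amino with the read-out staying inside the usual scatter, so this exchange does not separate the two compounds. No measured evidence bears on this result.

Going by these compounds, whether a carboxylic acid, a methoxy group or a dimethylamino group at this position would read differently remains open. So does whether the same exchange behaves alike elsewhere on the shared core.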